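The source may hold more compounds than are shown below. What is called first, only, known or untested is meant among the compounds shown, and "the series" means these compounds.

Measured so far in a functional assay on HepG2 cells (Homo sapiens) for inhibition, read by MTT assay, with a stated time of 72 h; a lower number here means a stronger inhibitor, a higher number a weaker inhibitor:

Compound 1 `CCc1ccccc1-n1cc(COc2cccc(NC(=O)Nc3ccc(Cl)c(C(F)(F)F)c3)c2)nn1`: 3530 nM
Compound 2 `CCc1ccc(-n2cc(COc3cccc(NC(=O)Nc4ccc(Cl)c(C(F)(F)F)c4)c3)nn2)cc1`: 1950 nM
Compound 3 `CC(C)c1ccccc1-n1cc(COc2cccc(NC(=O)Nc3ccc(Cl)c(C(F)(F)F)c3)c2)nn1`: 1900 nM

Compound 3 carries the lowest number of the three, but it stands within the scatter of the other two: the step of a 1.9-fold lower number from compound 1 to compound 3 (0.27 log units; within the scatter) and the step of a 1.0-fold lower number from compound 2 to compound 3 (0.01 log units; within the scatter) are both small, as is a 1.8-fold lower number from compound 1 to compound 2 (0.26 log units; within the scatter). Across these three, moving the ethyl from one position of the phenyl to another, or adding a methyl to turn the ethyl into an isopropyl, has not changed this assay beyond its scatter.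

Compound 4 `O=C(Nc1cccc(OCc2cn(-c3ccccc3F)nn2)c1)Nc1ccc(Cl)c(C(F)(F)F)c1` has not yet been measured. The change from compound 3 to compound 4 is fluoro in place of isopropyl on an aromatic carbon. For the measured compounds named here, nothing measured so far tests fluoro at that position, so the only guidance is the insensitivity of this assay to the three substituent variations already seen; none of those steps left the scatter. The expectation is therefore a step of a 1.3-fold higher number from compound 3 to compound 4 (0.12 log units; within the scatter), that is, no shift beyond the scatter in either direction. For compound 4 the estimate in this assay is 2500 nM, with a range from 1000 nM to 6000 nM.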

Compound 4, half-maximal inhibitory concentration: 1520 nM
For compound 4 the middle estimate is 1.6-fold (0.22 log units) above the measured one; the range from low to high includes it.
By their numbers in this assay, from the lowest: compounds 4, 3, 2 and 1 (each within the scatter of the next, the first and the last beyond it).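

Notes on the aryl group on the aromatic nitrogen, in this assay: on an aromatic carbon ortho to a large group, isopropyl with its 3 heavy atoms gives way to fluoro with its 1 heavy atom without a readable shift (the step of a 1.3-fold lower number from compound 3 to compound 4 (0.10 log units; within the scatter)), and the step to the 2-fluorophenyl from the 4-ethylphenyl also stays small (a 1.3-fold lower number from compound 2 to compound 4 (0.11 log units; within the scatter)). For the compounds shown here, the only new step to leave the scatter is fluoro in place of ethyl (a 2.3-fold lower number from compound 1 to compound 4 (0.37 log units; beyond the scatter)), and it is modest, so this position tolerates a fluorine as well as the alkyl groups but gains little from it. Group size does not order the position, since compound 3 with the larger isopropyl stays within the scatter of compound 4 while compound 1 with ethyl does not. Nothing available here bears on the reason for these steps.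

Going by these compounds alone, every group at this position so far is an alkyl group or fluoro, so a methoxy group, an amine or a carboxylic acid on the same aromatic carbon remains an open test of whether the flat response holds. Also open, going by these compounds, is whether a longer chain or a second fluoro on this phenyl would carry the number further beyond the scatter.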